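Spirooxindole series: amide-nitrogen methylation and paw edema

This account rests on a few compounds, and the source may have more. Where it says the series, first, only, none or still open, it means among the compounds named here.

Compound 1 `CN1C/C(=C\c2ccccc2)C(=O)[C@]2(C1)[C@@H](c1ccccc1)CN(C)[C@@]21C(=O)Nc2ccccc21` and compound 2 `CN1C/C(=C\c2ccccc2)C(=O)[C@]2(C1)[C@@H](c1ccccc1)CN(C)[C@@]21C(=O)N(C)c2ccccc21` share one core; compound 3 `Cc1ccc(/C=C2\CN(C)C[C@@]3(C2=O)[C@@H](c2ccc(C)cc2)CN(C)[C@@]32C(=O)Nc3ccccc32)cc1` and compound 4 `Cc1ccc(/C=C2\CN(C)C[C@@]3(C2=O)[C@@H](c2ccc(C)cc2)CN(C)[C@@]32C(=O)N(C)c3ccccc32)cc1` share another. The difference between the two cores is not broken down here.

In a functional assay on the whole organism (strain Wister albino) for inhibition, with Rattus norvegicus as the target, read by paw edema, with a stated time of 1 h, at a dose of 50 mg/kg by the intraperitoneal route (a lower number here means less inhibition, a higher number more inhibition at the dose given (going by the name of the read-out)), compound 1 gives 77%. Compound 2 gives 68% in this assay. The change between them is methyl in place of hydrogen on an amide-type nitrogen in a ring, and the step is a number 9 percentage points lower from compound 1 to compound 2 (within the scatter). Compound 3 gives 69.2% in this assay; its number and that of compound 2 lie within the scatter of one another, as do those of compound 3 and compound 1.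

The change from compound 3 to compound 4 is methyl in place of hydrogen on an amide-type nitrogen in a ring. It is the same change as that from compound 1 to compound 2, now made on the second core, and the place is described in the same words for both. Among the compounds shown the change occurs twice and has been measured once.

For the measured compounds named here, for compound 4 the expected step is a number 8.2 percentage points lower from compound 3 to compound 4 (within the scatter), taken directly from the one measured instance, because that instance is a number 9 percentage points lower from compound 1 to compound 2 (within the scatter) and lies within the scatter. A single pair cannot show whether the step repeats on the second core, so the range is kept wide. Compound 4 is expected to give about 61% in this assay, between 50% and 72%.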

Compound 4, a percentage reported as inhibition, in the whole organism at one dose (the size of the read-out at that dose, not a potency): 53.5%
Beside the measured number, compound 4's estimate is 7.5 percentage points above it, and the stated range covers the measured number.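

In this assay, methyl in place of hydrogen on the amide-type nitrogen in a ring gives a step on the second core that stands clear of the usual scatter, a number 15.7 percentage points lower from compound 3 to compound 4 (beyond the scatter). Set beside the first instance of the change, this step cannot be told apart from it, so the data give no sign that the core alters the effect of the change: the same change on two cores in this assay, a number 9 percentage points lower (within the scatter) from compound 1 to compound 2 and a number 15.7 percentage points lower (beyond the scatter) from compound 3 to compound 4, 6.7 percentage points apart, within the scatter of two such steps. This makes carrying the change from one core to the other a reasonable working assumption, but it does not show that the step has the same size on both cores, as the step on the first core alone stays within the scatter and two pairs at a single dose and time are thin support, nor does it explain why the number falls on the second core.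

The compounds shown leave open whether a longer chain on that nitrogen, such as ethyl or a chain ending in an amine or a carboxylic acid, would give a step like that of methyl. They also leave open which part of the difference between the two cores, not broken down here, bears on the size of the step.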